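Removing the sulfonamide nitrogen from a squalene monooxygenase inhibitor

This account rests on a few compounds, and the source may have more. Where it says the series, first, only, none or still open, it means among the compounds named here.

Of the compounds shown here, two have been measured in a functional assay on HepG2 cells for inhibition of squalene monooxygenase (Homo sapiens); a higher number here means a weaker inhibitor, a lower number a stronger inhibitor. Compound 1 `CCN(C/C=C/C#CC(C)(C)C)Cc1cccc(OCCN(C)S(=O)(=O)c2cc(Br)cs2)c1` gives 300 nM, and compound 2 `CCN(C/C=C/C#CC(C)(C)C)Cc1cccc(OCCN(CC)S(=O)(=O)c2cccs2)c1` gives 90 nM. Compound 2 thus holds the lowest of the two numbers, and the step of a 3.3-fold lower number from compound 1 to compound 2 (0.52 log units; beyond the scatter) shows it to be the stronger inhibitor of the pair.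

Compound 3 `CCN(C/C=C/C#CC(C)(C)C)Cc1cccc(OCCCS(=O)(=O)c2cccs2)c1` has not yet been measured in this assay. It differs from compound 2 in one place: a group of 9 heavy atoms (5 carbon, 2 oxygen, 2 sulfur; one five-membered aromatic ring with 1 hetero atom) in place of a group of 11 heavy atoms (6 carbon, 1 nitrogen, 2 oxygen, 2 sulfur; one five-membered aromatic ring with 1 hetero atom), on a saturated chain carbon, two bonds along the chain from an oxygen on an aromatic ring. For the measured compounds named here, the only measured step, from compound 1 to compound 2, concerns the same region of the molecule, but it exchanged one sulfonamide for another, whereas the change to compound 3 removes the nitrogen altogether and leaves a sulfone on a three-carbon chain. That step therefore bears only loosely on the present one, and nothing measured here tells how the nitrogen itself matters.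

On this basis compound 3 is expected to stay close to compound 2, with a slight weakening allowed, meaning an estimated step of a 1.7-fold higher number from compound 2 to compound 3 (0.22 log units; within the scatter). For compound 3 the estimate in this assay is 150 nM, within a range from 50 nM to 500 nM.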

Compound 3, half-maximal inhibitory concentration: 290 nM
For compound 3 the middle estimate is 1.9-fold (0.29 log units) below the measured one; the measured number falls inside the stated range.
By their numbers in this assay, from the lowest: compound 2; then compounds 3 and 1 (each within the scatter of the next).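

In this assay, replacing the ethyl((thiophen-2-yl)sulfonyl)amino group with the sulfone group of 9 heavy atoms weakens inhibition (a 3.2-fold higher number from compound 2 to compound 3 (0.51 log units; beyond the scatter)), a modest step that lies beyond the scatter. For the compounds shown here, the earlier pair exchanged only one sulfonamide for another, so this is the first sign that the group on this saturated chain carbon, two bonds along the chain from an oxygen on an aromatic ring, cannot lose its nitrogen and ethyl without a cost. The result also places compound 3 level with compound 1 (a 1.0-fold lower number from compound 1 to compound 3 (0.01 log units; within the scatter)), a difference within the scatter, so two quite different changes relative to compound 2 end at the same level.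

Since the nitrogen and its ethyl group leave together, the compounds shown cannot separate their contributions, and a sulfonamide with a hydrogen on the nitrogen, or an amide carbonyl in place of the sulfonyl, would be needed to do so. No measurement available here accounts for the loss in compound 3.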